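This account rests on a few compounds, and the source may have more. Where it says the series, first, only, none or still open, it means among the compounds named here.

Measured compounds and their values:

Compound 1 `C[C@@H]1O[C@H]([C@H]2CCCN2C)C[S@@+]1[O-]` — in an assay on CHO cells for binding affinity to muscarinic acetylcholine receptor M5 (Homo sapiens) (a higher number here means a weaker inhibitor, a lower number a stronger inhibitor), compound 1 gives < 100000 nM, which is a limit of the assay and not a number.

Compound 2 `C[C@H]1O[C@@H]([C@@H]2CCCN2C)C[S@+]1[O-]` — in this assay compound 2 gives < 100000 nM, again a limit and not a number.

For the measured compounds named here, the only measured step, from compound 1 to compound 2, is a step that the two limits leave unreadable from compound 1 to compound 2. Both ends sit at the limit (the limit of < 100000 nM in this assay, at which 2 of the 2 values shown sit), and the two are mirror images (the fact that compounds 1 and 2 differ only in the configuration as drawn), so nothing about size or direction can be read from it. Compound 2 therefore stands at a limit only, with no number of its own.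

Compound 3 `C[C@H]1O[C@@H]([C@@H]2CCCN2C)C[S@@+]1[O-]` differs from compound 2 in one place: the two compounds have the same atoms and bonds and differ only in configuration as drawn: 1 of 4 stereo elements differ; a stereocentre at a sulfur is drawn S in compound 2 and R in compound 3. Going by the values given here, no measured step resolves a change of this kind, so no step beyond the scatter can be predicted; the expected step from compound 2 to compound 3 is a step that the limit leaves unreadable from compound 2 to compound 3. Compound 3 is estimated at 60000 nM, within a range from 10000 nM to 200000 nM, with a high chance that the assay again reports only a limit.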

Compound 3, inhibition constant: < 100000 nM
Compound 3: no number, only a limit (the forecaster's own chance of this, stated with the estimate: 80%); the middle value is on the limit's open side.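

Compound 3 gives only a limit and not a number in this assay, as do compound 1 and compound 2, and no step among these three compounds can be read. The compounds shown leave open whether the configuration at sulfur or at the ring carbons changes the affinity at all.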